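The source may hold more compounds than are shown below. What is called first, only, known or untested is meant among the compounds shown, and "the series" means these compounds.

In an ADME assay on microsomes from liver (Rattus norvegicus) for metabolic stability, read by LC-MS, using NADPH, with a stated time of 90 min, tested at 1 uM (on this read-out higher numbers stand for a longer-lived compound and lower numbers for a shorter-lived compound), compound 1 `Fc1ccc(N2CCN(CCCc3c[nH]c4ccc(F)cc34)CC2)c(-c2cn[nH]c2)c1` gives 0.12 h and compound 2 `Fc1ccc(N2CCN(CCCc3c[nH]c4ccc(F)cc34)CC2)c(-c2cccnc2)c1` gives 0.0967 h, so the two values lie within the usual scatter of each other. Compound 3 `Fc1ccc(N2CCN(CCCc3c[nH]c4ccc(F)cc34)CC2)c(-c2cncnc2)c1` carries pyrimidin-5-yl in place of 1H-pyrazol-4-yl on an aromatic carbon. For the measured compounds named here, the one measured step that bears on this change, a 1.2-fold lower number from compound 1 to compound 2 (0.09 log units; within the scatter), puts pyridin-3-yl in place of the same group, so no shift beyond the scatter is expected in this assay. The expected step is a 1.1-fold lower number from compound 1 to compound 3 (0.04 log units; within the scatter). Compound 3 is estimated at 0.11 h, with an expected range from 0.05 h to 0.22 h.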

Compound 3, half-life: 0.11 h
The estimate for compound 3 equals the measured number at the digits printed; measured number inside the range.
By their numbers in this assay, from the lowest: compounds 2, 3 and 1 (each within the scatter of the next).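

In this assay, the 1H-pyrazol-4-yl with its hydrogen-bond donor gives way to pyrimidin-5-yl with 0 hydrogen-bond donors, which is a 1.1-fold lower number from compound 1 to compound 3 (0.04 log units; within the scatter), and the swap from pyridin-3-yl to pyrimidin-5-yl is a 1.1-fold higher number from compound 2 to compound 3 (0.06 log units; within the scatter). So three different aromatic rings on this aromatic carbon, ortho to a large group, all read within the scatter of one another. Nothing available here explains why these groups read alike. Still open, on these data alone, is whether a group of another kind at this place, such as an amine or a carboxylic acid, would move the half-life beyond the scatter. Also open, as far as these compounds go, is whether a change elsewhere, such as a longer chain in the shared core, would do so.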